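Aryl variation on the ring amine nitrogen: compound 4

A few compounds are considered here, and "the series" means these few. Any claim that something is new, unique, unknown or untested is made for them only; others in the source may bear on it.

The series keeps one core and varies the group on an amine nitrogen in a ring. Compound 1 `Nc1nc(N)c2cc(CSC(=S)N3CCN(c4ccc(O)cc4)CC3)ccc2n1` gives 5980 nM in a functional assay on HCT-116 cells (Homo sapiens) for antiproliferative activity, read by MTT assay, with a stated time of 72 h; a higher number here means a weaker inhibitor, a lower number a stronger inhibitor. Compound 2 `Cc1ccc(N2CCN(C(=S)SCc3ccc4nc(N)nc(N)c4c3)CC2)c(C)c1` gives 4070 nM in this assay, and compound 3 `Nc1nc(N)c2cc(CSC(=S)N3CCN(c4ccc(Cl)c(Cl)c4)CC3)ccc2n1` gives 6680 nM. Among these three numbers compound 1 stands second highest; its nearest neighbour is compound 3 and its furthest is compound 2, and both gaps are within the scatter. The measured steps are all of this kind: a 1.5-fold lower number from compound 1 to compound 2 (0.17 log units; within the scatter), a 1.1-fold higher number from compound 1 to compound 3 (0.05 log units; within the scatter) and a 1.6-fold higher number from compound 2 to compound 3 (0.22 log units; within the scatter). None of them leaves the scatter.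

Compound 4 `Nc1nc(N)c2cc(CSC(=S)N3CCN(c4ccc(F)cc4F)CC3)ccc2n1` differs from compound 1 as follows: 2,4-difluorophenyl in place of 4-hydroxyphenyl on an amine nitrogen in a ring. The three measured steps already cover a 2,4-dimethylphenyl, a 3,4-dichlorophenyl and a 4-hydroxyphenyl on the same amine nitrogen in a ring without any shift beyond the scatter, so for compound 4 no step beyond the scatter is expected in this assay, and the expected step is a 1.1-fold lower number from compound 1 to compound 4 (0.04 log units; within the scatter). The estimate for compound 4 is 5500 nM, with a range from 3000 nM to 11000 nM.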

Compound 4, half-maximal inhibitory concentration: 5150 nM
Compound 4: the middle estimate sits 1.1-fold (0.03 log units) above what was measured; the measured number falls inside the stated range.
By their numbers in this assay, from the lowest: compounds 2, 4, 1 and 3 (each within the scatter of the next).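

In this assay, 2,4-difluorophenyl on this amine nitrogen stays within the scatter of all three earlier aryl groups: a 1.2-fold lower number from compound 1 to compound 4 (0.06 log units; within the scatter), a 1.3-fold lower number from compound 3 to compound 4 (0.11 log units; within the scatter) and a 1.3-fold higher number from compound 2 to compound 4 (0.10 log units; within the scatter). Fluorine thus adds a fourth kind of substituent on the phenyl ring, and the four compounds remain within the scatter of one another. The change from compound 1 also removes the hydrogen-bond donor and acceptor counted on 4-hydroxyphenyl, with no step beyond the scatter in this series.

All the groups shown at this position are substituted phenyl rings, so the outcome with a benzyl group, a pyridine ring, a simple alkyl chain or a phenyl ring bearing an amine remains open. No supporting measurement is available to explain why the values stay this close.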